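The source may hold more compounds than are shown below. What is called first, only, known or untested is meant among the compounds shown, and "the series" means these compounds.

Measured compounds and their values in an ADME assay on WI-38 cells (Homo sapiens) for inhibition, read by MTT assay, with a stated time of 72 h; a lower number here means a stronger inhibitor, a higher number a weaker inhibitor:

Compound 1, `Cc1ccc(C(=O)OC2(C(=O)Nc3ccc([N+](=O)[O-])cc3)CCCCC2)cc1`, gives 32 nM.
Compound 2, `O=C(OC1(C(=O)Nc2ccc([N+](=O)[O-])cc2)CCCCC1)c1ccc(Cl)cc1`, gives 355 nM.

Going by the values given here, compound 2 holds the higher of the two measured values in this assay, so it is the weaker inhibitor of the pair; the only step known, an 11-fold higher number from compound 1 to compound 2 (1.05 log units; beyond the scatter), is a large one. The unmeasured compound 3, `COc1ccc(C(=O)OC2(C(=O)Nc3ccc([N+](=O)[O-])cc3)CCCCC2)cc1`, differs from compound 2 in one place: methoxy in place of chloro on an aromatic carbon.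

Among the compounds with values here, no measured step shows what methoxy does at this place. The step from compound 1 to compound 2 bears on it only indirectly: it shows that swapping the group at this place can move the value by a large amount, in this case upward when methyl gave way to chloro. Methoxy is a third group, distinct from both, so the direction is open. A move back toward compound 1 is as plausible as a further rise, and the expected step of a 2.4-fold lower number from compound 2 to compound 3 (0.37 log units; beyond the scatter) is therefore set near no change, with a wide range. Compound 3 is estimated at 150 nM, between 25 nM and 900 nM.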

Compound 3, half-maximal inhibitory concentration: 40 nM
For compound 3 the middle estimate is 3.8-fold (0.57 log units) above the measured one; the range from low to high includes it.
By their numbers in this assay, from the lowest: compounds 1 and 3 (each within the scatter of the next); then compound 2.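

In this assay, methoxy in place of chloro gives an 8.9-fold lower number from compound 2 to compound 3 (0.95 log units; beyond the scatter), so the high number of compound 2 does not carry over to every new group at this spot on the aromatic ring. Methoxy in place of methyl gives a 1.3-fold higher number from compound 1 to compound 3 (0.10 log units; within the scatter), so this assay does not separate these two groups, even though they differ in their atoms. Among the three groups shown, chloro is therefore the one that stands apart, with compound 2 the weakest inhibitor of the set, while compound 1 and compound 3 stay together within the scatter.

No supporting measurement bears on why chloro behaves differently from methyl and methoxy here. From the compounds shown here alone, it also remains open whether other groups at this place, such as fluoro, bromo, an amine or a hydroxyl, would side with chloro or with the pair of methyl and methoxy, and whether a longer chain such as ethoxy would keep the value of compound 3.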